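Ethoxymethyl to methoxymethyl on the shared core

The source may hold more compounds than are shown below. What is called first, only, known or untested is meant among the compounds shown, and "the series" means these compounds.

Measured so far in a functional assay on MDA-MB-231 cells (Homo sapiens) for cytotoxicity, read by sulforhodamine B assay, with a stated time of 3 days (on this read-out higher numbers stand for an effect only at larger amounts of compound and lower numbers for an effect already at smaller amounts), for this series:
- compound 1 `CCOCc1c(C)coc1-c1ccc2c(c1OC)CCCC2(C)C` gives 42.7 uM in this read-out
- compound 2 `Cc1coc(-c2ccc3c(c2O)CCCC3(C)C)c1CO` gives 39.5 uM in this read-out

Compound 1 stands level with compound 2: their two values lie within the usual scatter of each other. Compound 3 `COCc1c(C)coc1-c1ccc2c(c1OC)CCCC2(C)C` is not yet measured. The structural difference from compound 1 is hydrogen in place of methyl on a saturated chain carbon bound to an oxygen on a saturated carbon and reads as hydrogen in place of methyl on a saturated chain carbon bound to an oxygen on a saturated carbon, or ethoxymethyl to methoxymethyl. Among the compounds with values here, no measured pair shows this change on its own, so the expectation has little to rest on. Within the data shown here, the only reference points are compound 1 at 42.7 uM and compound 2 at 39.5 uM in close agreement. In this assay no step beyond the scatter is expected in either direction. The expected step is a 1.1-fold lower number from compound 1 to compound 3 (0.03 log units; within the scatter) and it stays within the scatter. For compound 3 the estimated value is 40 uM with an expected range from 20 uM to 80 uM as the likely span.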

Compound 3, concentration for half-maximal effect: 47.8 uM
For compound 3 the middle estimate is 1.2-fold (0.08 log units) below the measured one, within the range that was stated.
By their numbers in this assay, from the lowest: compounds 2, 1 and 3 (each within the scatter of the next).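

In this assay, within the data shown here, the change from ethoxymethyl to methoxymethyl gives a 1.1-fold higher number from compound 1 to compound 3 (0.05 log units; within the scatter) and is the first single-place comparison. Hydrogen in place of methyl on a saturated chain carbon bound to an oxygen on a saturated carbon therefore leaves the read-out within the usual scatter, so ethoxymethyl and methoxymethyl cannot be told apart here on the shared core. No supporting data on hand bear on the reason for this result.

The pair covers only these two small ether side chains at one position, so it does not show whether this position tolerates every change or whether the read-out simply does not respond to this small one. A longer chain such as butoxymethyl, or an aminomethyl or carboxylic acid group in place of the ether, would test whether any group at this position can move the number in this assay beyond the scatter.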